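The source may report more compounds than this note shows. Statements on the series, on what has been measured and on what is new or still open speak of the compounds shown alone.

Measured so far in an ADME assay on PC-3 cells (Homo sapiens) for cytotoxicity, read by CCK-8 assay, with a stated time of 6 days; a higher number here means a weaker inhibitor, a lower number a stronger inhibitor:

Compound 1 `CC(O)c1cccc(C(=O)N[C@@H](C)Cn2ccc(-c3ccc(C#N)c(Cl)c3)n2)c1` gives > 30000 nM, which is a limit of the assay and not a number.
Compound 2 `CC(O)c1ccc(C(=O)N[C@@H](C)Cn2ccc(-c3ccc(C#N)c(Cl)c3)n2)cc1` gives > 30000 nM, again a limit.
Compound 3 `COC(=O)/C=C/C(=O)N[C@@H](C)Cn1ccc(-c2ccc(C#N)c(Cl)c2)n1` gives > 30000 nM, again a limit.

Compound 3 thus stands at the limit, and so does every other value measured here: the limit of > 30000 nM in this assay, at which 3 of the 3 values shown sit. The three steps among the measured compounds, a step that the two limits leave unreadable from compound 1 to compound 2, a step that the two limits leave unreadable from compound 1 to compound 3 and a step that the two limits leave unreadable from compound 2 to compound 3, are all unreadable for that reason; their size and direction cannot be drawn from the data.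

Compound 4 `Cc1ccnc(N[C@@H](C)Cn2ccc(-c3ccc(C#N)c(Cl)c3)n2)n1` differs from compound 3 in one place: 4-methylpyrimidin-2-yl in place of (2-(methoxycarbonyl)ethenyl)carbonyl on an amine nitrogen. Among the compounds with values here, none of the measured steps concerns this amine nitrogen, and none of them is readable in any case, so no measured step bears on the change. With every value in the series at the limit, the expectation for compound 4 can rest only on that fact. The step of a number no higher from compound 3 to compound 4 (the limit leaves the size open) is expected to be none that the assay can resolve. Compound 4 is therefore expected to give 30000 nM, with a range from 6000 nM to 60000 nM, most likely reported as a limit once more.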

Compound 4, half-maximal inhibitory concentration: > 30000 nM
Compound 4 ended at the assay's limit; the forecaster's own chance of this, stated with the estimate: 80%; the middle value lies on the limit itself.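

Compound 3 and compound 4 both stand at a limit and not at a number, so no step between them can be read: the limit of > 30000 nM in this assay, at which 4 of the 4 values shown sit.

The compounds shown leave open which change to the shared core, if any, would give a readable value.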